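Working notes on compound 4 and its measured neighbours

The compounds below may be only part of what the source reports. "The series", "measured", "known", "first", "only" and "open" are said of these compounds alone.

Measured so far in an assay on CHO cells for antagonist activity at transient receptor potential cation channel subfamily V member 1 (Homo sapiens), read by FLIPR; a lower number here means a stronger inhibitor, a higher number a weaker inhibitor: compound 1 `CC(C(=O)NCc1ccc(C(F)(F)F)cc1N1CCCC1)c1ccc(NS(C)(=O)=O)c(F)c1` gives 2.3 nM; compound 2 `CC1CCN(c2cc(C(F)(F)F)ccc2CNC(=O)C(C)c2ccc(NS(C)(=O)=O)c(F)c2)CC1` gives 0.9 nM; compound 3 `CC(C(=O)NCc1ccc(C(F)(F)F)cc1N1CCC(Cc2ccccc2)CC1)c1ccc(NS(C)(=O)=O)c(F)c1` gives 1.4 nM.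

Compound 2 holds the lowest number of the three, though compound 3 lies within the scatter of it: a 1.6-fold higher number from compound 2 to compound 3 (0.19 log units; within the scatter). Among the compounds with values here, the one step beyond the scatter is a 2.6-fold lower number from compound 1 to compound 2 (0.41 log units; beyond the scatter), a modest gain from the ring enlargement.

Compound 4 `CCCOc1cc(C(F)(F)F)ccc1CNC(=O)C(C)c1ccc(NS(C)(=O)=O)c(F)c1` differs from compound 2 in one place: propoxy in place of 4-methylpiperidin-1-yl on an aromatic carbon. Within the data shown here, only the step from compound 1 to compound 2 bears on this, and only loosely, as no measured step removes the ring amine altogether. A modest step upward in this assay is therefore expected, a 3.9-fold higher number from compound 2 to compound 4 (0.59 log units; beyond the scatter). For compound 4 the estimate is 3.5 nM, range 1 nM to 15 nM.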

Compound 4, inhibition constant: 2 nM
Estimate against measurement, compound 4: 1.8-fold (0.24 log units) above; the range from low to high includes it.
By their numbers in this assay, from the lowest: compounds 2, 3, 4 and 1 (each within the scatter of the next, the first and the last beyond it).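

The position on this aromatic carbon does not depend on a ring amine: propoxy, with no ring, keeps the number in the low nanomolar range in this assay. The change from 4-methylpiperidin-1-yl carries a modest cost, a 2.2-fold higher number from compound 2 to compound 4 (0.35 log units; beyond the scatter), whereas the change from pyrrolidin-1-yl gives no readable difference, a 1.2-fold lower number from compound 1 to compound 4 (0.06 log units; within the scatter). No measurement at hand accounts for either step.

Open, as far as these compounds go, is whether the ether oxygen or the chain length matters more here. A propylamino group or a butoxy chain at this position would separate the two.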